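This account rests on a few compounds, and the source may have more. Where it says the series, first, only, none or still open, it means among the compounds named here.

Measured in a functional assay on HCT-116 cells (Homo sapiens) for antiproliferative activity, read by CCK-8 assay, with a stated time of 48 h; on this read-out higher numbers stand for weaker inhibition and lower numbers for stronger inhibition:
- compound 1 `O=C(CCCCCCC(=O)NCCNc1nonc1/C(=N/O)Nc1ccc(F)c(Br)c1)NO`: 4700 nM
- compound 2 `O=C(CCCCC(=O)NCCNc1nonc1/C(=N/O)Nc1ccc(F)c(Br)c1)NO`: 85400 nM

Compound 2, at 85400 nM, holds the higher of the two numbers and so shows the weaker inhibition. Next in line is compound 3 `O=C(CCCCCC(=O)NCCNc1nonc1/C(=N/O)Nc1ccc(F)c(Br)c1)NO`, not yet measured. Its change from compound 2 is (hydroxycarbamoyl)methyl in place of hydroxycarbamoyl on a saturated chain carbon, four bonds along the chain from a carbonyl carbon.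

Going by the values given here, only one measured step bears on this: an 18-fold higher number from compound 1 to compound 2 (1.26 log units; beyond the scatter), where hydroxycarbamoyl replaced 2-(hydroxycarbamoyl)ethyl at the same place. The group in compound 3 falls between those two, so part of that large step should be recovered, although a single step shows no trend. In this assay, the expected change is a 4.3-fold lower number from compound 2 to compound 3 (0.63 log units; beyond the scatter), towards a lower number and probably beyond the scatter. For compound 3 the estimated value is 20000 nM, with an expected range of 7000 nM to 60000 nM.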

Compound 3, half-maximal inhibitory concentration: 17500 nM
Compound 3: the middle estimate sits 1.1-fold (0.06 log units) above what was measured; measured number inside the range.
By their numbers in this assay, from the lowest: compound 1; then compound 3; then compound 2.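

In this assay, the chain position now holds three points, and the change from the earlier single large step resolves into two smaller ones, both beyond the scatter: going from hydroxycarbamoyl to (hydroxycarbamoyl)methyl gives one (a 4.9-fold lower number from compound 2 to compound 3 (0.69 log units; beyond the scatter)), and compound 1, carrying 2-(hydroxycarbamoyl)ethyl at the same place, stays ahead of the new compound (a 3.7-fold higher number from compound 1 to compound 3 (0.57 log units; beyond the scatter)). Across these three compounds the number falls as the chain grows, none of them goes against that order, and the loss seen with the shortest chain is therefore graded and not confined to one chain length.

Open, from the compounds shown here alone, is whether 3-(hydroxycarbamoyl)propyl or a still longer chain lowers the number further or reverses the order, and whether a carboxylic acid at the chain end could stand in for the hydroxycarbamoyl group. No measurement on hand explains the dependence on chain length.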